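Removing the methoxy group from compound 3

The compounds below may be only part of what the source reports. "The series", "measured", "known", "first", "only" and "open" are said of these compounds alone.

Compound 3 `CCn1c(SCC(=O)Nc2ccc(C(C)=O)cc2)nnc1-c1ccc(OC)cc1` gives 62% in a functional assay on the whole organism (strain albino) for inhibition, with Rattus norvegicus as the target, read by paw edema, with stated times of 30 min and 5 h, at a dose of 0.28 mmol/kg by the oral route (on this read-out higher numbers stand for more inhibition at the one dose given (going by the name of the read-out) and lower numbers for less inhibition), and stands lowest of three numbers, yet within the usual scatter of compound 1 `C=CCn1c(SCC(=O)Nc2ccc(C(C)=O)cc2)nnc1-c1ccccc1` with 63% and of compound 2 `CCn1c(SCC(=O)Nc2ccc(/C(C)=N/O)cc2)nnc1-c1ccc(OC)cc1` with 65% in this assay. Among the measured compounds shown here, the one single-point step measured so far, a number 3 percentage points lower from compound 2 to compound 3 (within the scatter) in this assay, concerns a different part of the molecule. Compound 4 `CCn1c(SCC(=O)Nc2ccc(C(C)=O)cc2)nnc1-c1ccccc1` differs from compound 3 by hydrogen in place of methoxy on an aromatic carbon and nothing else. For the measured compounds named here, no measured pair isolates this change; compound 1 and compound 3 differ at two places at once, and their values sit close together. The step of a number 1 percentage points higher from compound 3 to compound 4 (within the scatter) is therefore expected to stay within the scatter. Compound 4 is expected to give 63% with a range from 53% to 73% for this estimate.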

Compound 4, a percentage reported as inhibition, in the whole organism at one dose (the size of the read-out at that dose, not a potency): 66%
Estimate against measurement, compound 4: 3 percentage points below; low and high end bracket the measured number.
By their numbers in this assay, from the lowest: compounds 3, 1, 2 and 4 (each within the scatter of the next).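

In this assay, the step to the unsubstituted ring, a number 4 percentage points higher from compound 3 to compound 4 (within the scatter), shows that 4-methoxyphenyl to phenyl does not move the number beyond the scatter, so this methoxy group is not required for the effect at this dose. The step of a number 3 percentage points higher from compound 1 to compound 4 (within the scatter), with methyl in place of vinyl on the chain on the aromatic nitrogen, likewise stays within the scatter. Nothing measured here explains either result. On these data alone, whether an amine or a carboxylic acid at this place on the ring, or a longer chain on the aromatic nitrogen, would shift the number beyond the scatter remains open.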